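Swapping a pyridine amine for a cyclopropyl amine

The source may hold more compounds than are shown below. What is called first, only, known or untested is meant among the compounds shown, and "the series" means these compounds.

Three compounds share one core and differ only in the amine at the end of the side chain. Compound 1 `CC(=O)NC[C@H]1CN(c2ccc(OC[C@H](O)CNc3ccccn3)c(F)c2)C(=O)O1` gives 35100000 nM in a physicochemical assay for solubility, read by HPLC; on this read-out higher numbers stand for higher solubility and lower numbers for lower solubility. Compound 2 `CC(=O)NC[C@H]1CN(c2ccc(OC[C@@H](O)CNc3cccnc3)c(F)c2)C(=O)O1` gives 3040000 nM in this assay, and compound 3 `CC(=O)NC[C@H]1CN(c2ccc(OC[C@@H](O)CNc3ccncc3)c(F)c2)C(=O)O1` gives 17700000 nM. Compound 3 thus stands second highest of the three: its number lies within the scatter of compound 1, while a 5.8-fold higher number from compound 2 to compound 3 (0.77 log units; beyond the scatter).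

Compound 4 `CC(=O)NC[C@H]1CN(c2ccc(OC[C@H](O)CNC3CC3)c(F)c2)C(=O)O1` is not yet measured. The change from compound 3 is 2-(cyclopropylamino)-1-hydroxyethyl in place of 1-hydroxy-2-((pyridin-4-yl)amino)ethyl on a saturated chain carbon bound to an oxygen on an aromatic ring. For the measured compounds named here, no measured step makes this kind of exchange; the known steps only move the ring nitrogen, and these were a 12-fold lower number from compound 1 to compound 2 (1.06 log units; beyond the scatter) and a 2.0-fold lower number from compound 1 to compound 3 (0.30 log units; within the scatter). They show that small changes in this part of the molecule can shift the number considerably, in this case downward, so a step beyond the scatter in either direction is possible, though its direction cannot be read from these three compounds. Compound 4 is therefore expected to give 10000000 nM, within the range 2000000 nM to 50000000 nM. The estimated step is a 1.8-fold lower number from compound 3 to compound 4 (0.25 log units; within the scatter).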

Compound 4, solubility: 2200000 nM
Estimate against measurement, compound 4: 4.5-fold (0.66 log units) above; low and high end bracket the measured number.
By their numbers in this assay, from the lowest: compounds 4 and 2 (each within the scatter of the next); then compounds 3 and 1 (each within the scatter of the next).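

For the compounds shown here, replacing the pyridine ring with a cyclopropyl on the amine nitrogen is the first change here that removes the aromatic ring rather than moving its nitrogen, and in this assay it gives an 8.0-fold lower number from compound 3 to compound 4 (0.91 log units; beyond the scatter) and a 16-fold lower number from compound 1 to compound 4 (1.20 log units; beyond the scatter). Compound 2 goes against a general drop, with a 1.4-fold lower number from compound 2 to compound 4 (0.14 log units; within the scatter), so the size of the step depends on which pyridine it starts from. Going by these compounds alone, the direction that the earlier compounds left open is therefore downward from the pyridin-2-yl and pyridin-4-yl compounds, while the pyridin-3-yl and cyclopropyl compounds stand level within the scatter.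

Nothing at hand gives a reason for these steps. As far as these compounds go, whether a larger saturated ring such as cyclohexyl, or an open chain such as isopropyl, on the same amine nitrogen would stay at this level remains open.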